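The compounds below may be only part of what the source reports. "The series", "measured", "known", "first", "only" and "open" are said of these compounds alone.

Compound 1 `Nc1sc2c(c1-c1nc3ccccc3s1)CCCC2` and compound 2 `C(=N/c1sc2c(c1-c1nc3ccccc3s1)CCCC2)\c1ccccc1` share one core, and both have been tested in an ADME assay on HeLa cells (Homo sapiens) for cytotoxicity, read by MTT assay, with a stated time of 72 h; a higher number here means that more compound is tolerated, a lower number that less compound is tolerated. In that assay compound 1 gives 475 ug/mL, and compound 2 gives 333 ug/mL. Going by the values given here, the one step measured so far, a 1.4-fold lower number from compound 1 to compound 2 (0.15 log units; within the scatter), puts a ring-bearing group in place of a single nitrogen atom and stays within the scatter, so compound 2 stands beside compound 1 with two numbers that do not separate.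

Compound 3 `Fc1ccccc1/C=N/c1sc2c(c1-c1nc3ccccc3s1)CCCC2` differs from compound 2 by fluoro in place of hydrogen on an aromatic carbon. Among the compounds with values here, no measured step tests a fluoro for hydrogen exchange, and the one step known, a 1.4-fold lower number from compound 1 to compound 2 (0.15 log units; within the scatter), touched a different part of the molecule and moved the number only within the scatter. The step from compound 2 to compound 3 is therefore expected to be a 1.0-fold lower number from compound 2 to compound 3 (0.00 log units; within the scatter), with no direction beyond the scatter. For compound 3 the estimate in this assay is 330 ug/mL, within 180 ug/mL to 600 ug/mL.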

Compound 3, half-maximal cytotoxic concentration: 426 ug/mL
Compound 3: the middle estimate sits 1.3-fold (0.11 log units) below what was measured, within the range that was stated.
By their numbers in this assay, from the lowest: compounds 2, 3 and 1 (each within the scatter of the next).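

In this assay the change from phenyl to 2-fluorophenyl, the first exchange tested on this aromatic ring itself, gives a 1.3-fold higher number from compound 2 to compound 3 (0.11 log units; within the scatter) and so does not separate compound 3 from compound 2. With fluoro in this place, ortho to a large group, the wider exchange on the shared core gives a 1.1-fold lower number from compound 1 to compound 3 (0.05 log units; within the scatter) and leaves compound 3 level with compound 1 as well. No measurement is at hand that bears on the reason for these results.

The compounds shown leave open whether another group on this ring, such as an amine or a carboxylic acid, would give a step beyond the scatter. They also leave open whether a longer chain in place of the ring would do so.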